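This account rests on a few compounds, and the source may have more. Where it says the series, first, only, none or still open, it means among the compounds named here.

Working notes on the series, all read in a functional assay on V79 cells (Cricetulus griseus) for cytotoxicity, read by colony formation; on this read-out lower numbers stand for stronger inhibition and higher numbers for weaker inhibition. Among the measured compounds shown here, compound 3 `NC1CCN(c2c(F)cc3c(=O)c(C(=O)O)cn(C4CC4)c3c2F)CC1` gives 23 ug/mL and holds the lowest number so far. The nearest is compound 2 `CC1(CN)CCN(c2c(F)cc3c(=O)c(C(=O)O)cn(C4CC4)c3c2C(F)(F)F)C1`, which gives 110 ug/mL as a higher number, and that gap lies beyond the scatter. Compound 1 `NC1CCN(c2c(F)cc3c(=O)c(C(=O)O)cn(C4CC4)c3c2C(F)(F)F)C1` gives 300 ug/mL; 300 ug/mL; 300 ug/mL (3 entries) on each of its entries. The step of interest leads to compound 4 `NC1CCN(c2c(F)cc3c(=O)c(C(=O)O)cn(C4CC4)c3c2C(F)(F)F)CC1`, which keeps the 4-aminopiperidin-1-yl group of compound 3 and has trifluoromethyl in place of fluoro on an aromatic carbon. For the measured compounds named here, no measured pair isolates this swap. Going by the values given here, the only guide is indirect: compound 2 at 110 ug/mL and compound 1 at 300 ug/mL; 300 ug/mL; 300 ug/mL (3 entries) both carry trifluoromethyl, though each with a different amine group. A move toward weaker inhibition, beyond the scatter, is therefore expected, with an estimated 4.3-fold higher number from compound 3 to compound 4 (0.64 log units; beyond the scatter) as its size. The estimate for compound 4 is 100 ug/mL with an expected range of 35 ug/mL to 300 ug/mL in this read-out.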

Compound 4, half-maximal inhibitory concentration: 20 ug/mL
The estimate for compound 4 lay 5.0-fold (0.70 log units) above the measured number, and the stated range ends above it.
By their numbers in this assay, from the lowest: compounds 4 and 3 (each within the scatter of the next); then compound 2.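

In this assay, trifluoromethyl in place of fluoro on this aromatic carbon, ortho to a 4-aminopiperidin-1-yl group, gives a 1.2-fold lower number from compound 3 to compound 4 (0.06 log units; within the scatter) and so leaves the read-out within the scatter despite the larger group. Among the compounds shown here, this is the first direct reading of the swap, and with the 4-aminopiperidin-1-yl group held, trifluoromethyl here does not separate the pair. With trifluoromethyl held, 4-aminopiperidin-1-yl in place of 3-(aminomethyl)-3-methylpyrrolidin-1-yl gives a 5.5-fold lower number from compound 2 to compound 4 (0.74 log units; beyond the scatter) and places the larger gap with the amine group; no measurement at hand accounts for either step.

The compounds shown carry only fluoro or trifluoromethyl on this carbon, so how a chloro, methyl or methoxy group would read there remains open. Also open, as far as these compounds go, is whether the swap reads the same with the amine group of compound 2.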